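Moving the chlorine around the ring at the chain end

The compounds below may be only part of what the source reports. "The series", "measured", "known", "first", "only" and "open" are said of these compounds alone.

Going by the values given here, compound 2 `O=C(CCCCCCc1ccccc1Cl)c1ncc(-c2ccccn2)o1` is the only compound here that gives an actual number in an assay for inhibition of Fatty-acid amide hydrolase 1 (Rattus norvegicus); a higher number here means a weaker inhibitor, a lower number a stronger inhibitor; compound 2 gives 1.9 nM. Compound 1 `O=C(O)c1ccc(CCCCCCC(=O)c2ncc(-c3ccccn3)o2)cc1` gives only a limit of the assay in this assay, > 600 nM, which is the limit described by the limit of > 600 nM in this assay, at which 1 of the 2 values shown sits. Among the compounds with values here, the one measured step, an at least 310-fold lower number from compound 1 to compound 2 (2.49 log units; beyond the scatter), is the only comparison available, and it swaps the whole group at the chain end rather than shifting a single atom around a ring.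

Compound 3 `O=C(CCCCCCc1ccc(Cl)cc1)c1ncc(-c2ccccn2)o1` differs from compound 2 by 4-chlorophenyl in place of 2-chlorophenyl on a saturated chain carbon, six bonds along the chain from a carbonyl carbon. This change keeps the chlorine and the ring but alters where the chlorine sits; the measured step says nothing directly about such a shift, since it replaced 4-carboxyphenyl with 2-chlorophenyl in one move. Within the data shown here, no measured step therefore points to a large change, and the expected step is small, a 1.6-fold higher number from compound 2 to compound 3 (0.20 log units; within the scatter), which may well sit within the scatter. For compound 3 the estimate in this assay is 3 nM, within a range from 0.7 nM to 15 nM.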

Compound 3, inhibition constant: 2.7 nM
Beside the measured number, compound 3's estimate is 1.1-fold (0.05 log units) above it, and the stated range covers the measured number.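

With 4-chlorophenyl in place of 2-chlorophenyl, this assay shows a 1.4-fold higher number from compound 2 to compound 3 (0.15 log units; within the scatter), so the two placements of the chlorine cannot be told apart on this read-out. The other new comparison, with chloro in place of carboxy on an aromatic carbon, is an at least 220-fold lower number from compound 1 to compound 3 (2.34 log units; beyond the scatter), and it isolates a change of a single group on the ring, which the earlier step could not do because it also moved the substituent. In these three compounds, then, which group the ring carries makes a large difference, while the two chlorine placements give values within the scatter, and the size of the large step is only a bound since compound 1 gives a limit of the assay: the limit of > 600 nM in this assay, at which 1 of the 3 values shown sits.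

On these data alone, whether a plain phenyl, a fluoro or methoxy group in place of the chloro, or an amine at the chain end would give similar numbers remains open, as does the effect of a longer or shorter chain. As far as these compounds go, all of this rests on one assay against the rat enzyme, so how these compounds behave against any other protein also stays unknown.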